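Cytotoxicity of a Nitroimidazooxazine Series: A Methyl Swap

A few compounds are considered here, and "the series" means these few. Any claim that something is new, unique, unknown or untested is made for them only; others in the source may bear on it.

Cytotoxicity toward human lung fibroblast cells was followed in an ADME assay on MRC5 cells (Homo sapiens) for cytotoxicity, read by resazurin assay, with a stated time of 72 h; a higher number here means a weaker inhibitor, a lower number a stronger inhibitor. Compound 1 `CN(CC1CCn2cc([N+](=O)[O-])nc2O1)c1ccc(OC(F)(F)F)cc1` pairs a shared bicyclic core with a side arm ending in an aryl ring bearing a trifluoromethoxy group. In this assay compound 1 gives >= 40000 nM, which is a limit of the assay and not a number. Compound 2 `CN(CC1(C)CCn2cc([N+](=O)[O-])nc2O1)c1ccc(OC(F)(F)F)cc1` differs from compound 1 by methyl in place of hydrogen on a saturated ring carbon. In this assay compound 2 gives >= 40000 nM, again only a limit. The step that the two limits leave unreadable from compound 1 to compound 2 therefore cannot be read. Compound 3 `O=C(NCc1ccc(OC(F)(F)F)cc1)OCC1CCn2cc([N+](=O)[O-])nc2O1` carries a carbamate side arm instead; how its core region differs from that of compound 1 is not broken down here. In this assay compound 3 gives >= 40000 nM, also a limit. Compound 4 `CC1(COC(=O)NCc2ccc(OC(F)(F)F)cc2)CCn2cc([N+](=O)[O-])nc2O1`, not yet measured, differs from compound 3 by methyl in place of hydrogen on a saturated ring carbon, the same change as that made between compound 1 and compound 2, at the same place. Because (the limit of >= 40000 nM in this assay, at which 3 of the 3 values shown sit), compound 4 is expected to stay at that limit as well, a step of a number no higher from compound 3 to compound 4 (the limit leaves the size open). In this assay compound 4 is estimated at 40000 nM, expected between 20000 nM and 80000 nM.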

Compound 4, half-maximal inhibitory concentration: >= 40000 nM
Compound 4: no number, only a limit; the forecaster's own chance of this, stated with the estimate: 90%; the middle value sits exactly at the limit.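

Compound 4 gives >= 40000 nM in this assay, again a limit of the assay and not a number. With compound 3 also at a limit, no step can be read between compound 3 and compound 4. How strongly any of these compounds affects the cells, and whether the methyl changes that at all, stays open, with every value resting on one mark: the limit of >= 40000 nM in this assay, at which 4 of the 4 values shown sit.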